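A few compounds are considered here, and "the series" means these few. Any claim that something is new, unique, unknown or untested is made for them only; others in the source may bear on it.

Three compounds from this series have numbers in a functional assay on HT-29 cells (Homo sapiens) for cytotoxicity, read by MTT assay, with a stated time of 72 h; on this read-out higher numbers stand for weaker inhibition and lower numbers for stronger inhibition. Compound 1 `CN(C)CCn1cnnc1-c1cc(Oc2ccc(NC(=O)N/N=C/c3ccccc3)cc2F)ccn1` gives 1120 nM in this assay. Compound 2 `CN(C)CCn1cnnc1-c1cc(Oc2ccc(NC(=O)N/N=C/c3cccc(Cl)c3Cl)cc2F)ccn1` gives 130 nM, and compound 3 `CN(C)CCn1cnnc1-c1cc(Oc2ccc(NC(=O)N/N=C/c3cc(Br)c(O)c(Br)c3)cc2F)ccn1` gives 2670 nM. Compound 3 therefore has the highest number of the three, with compound 1 nearest (a 2.4-fold higher number from compound 1 to compound 3 (0.38 log units; beyond the scatter)) and compound 2 furthest (a 21-fold higher number from compound 2 to compound 3 (1.31 log units; beyond the scatter)). The step from compound 1 to compound 2 shows what a different pattern of substituents on the same ring can do: an 8.6-fold lower number from compound 1 to compound 2 (0.94 log units; beyond the scatter).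

Compound 4 `COc1ccc(/C=N/NC(=O)Nc2ccc(Oc3ccnc(-c4nncn4CCN(C)C)c3)c(F)c2)cc1O` keeps the shared core and changes only the ring on the carbon with a double bond to nitrogen: 3-hydroxy-4-methoxyphenyl in place of 3,5-dibromo-4-hydroxyphenyl on a carbon with a double bond to nitrogen. Among the measured compounds shown here, no measured pair shows a 3-hydroxy-4-methoxyphenyl, so the size of this step can only be guessed from the steps already seen on that ring, which ranged from modest to large. Since compound 3 sits at the weak end, the expectation is a moderate move back toward the number of compound 1, as a 1.8-fold lower number from compound 3 to compound 4 (0.25 log units; within the scatter). Compound 4 is thus estimated at 1500 nM, within a range of 400 nM to 5500 nM.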

Compound 4, half-maximal inhibitory concentration: 960 nM
For compound 4 the middle estimate is 1.6-fold (0.19 log units) above the measured one; measured number inside the range.
By their numbers in this assay, from the lowest: compound 2; then compounds 4 and 1 (each within the scatter of the next); then compound 3.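

In this assay, the 3-hydroxy-4-methoxyphenyl ring of compound 4 stands level with the unsubstituted phenyl ring (a 1.2-fold lower number from compound 1 to compound 4 (0.07 log units; within the scatter)), so adding these groups to the ring leaves the number within the scatter. A hydroxyl on the ring does not by itself bring a weak result: both 3,5-dibromo-4-hydroxyphenyl and 3-hydroxy-4-methoxyphenyl carry one, yet the change between them gives a clear shift (a 2.8-fold lower number from compound 3 to compound 4 (0.44 log units; beyond the scatter)), while the 2,3-dichlorophenyl ring keeps its clear lead (a 7.4-fold higher number from compound 2 to compound 4 (0.87 log units; beyond the scatter)). No measurement at hand bears on why these numbers differ.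

The compounds shown leave open how a ring bearing an amine or a carboxylic acid would behave at this position. They also leave open whether a single chlorine would keep the low number of compound 2.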